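Swapping Bromo for Ethoxy on the Aryl Substituent

The source may report more compounds than this note shows. Statements on the series, on what has been measured and on what is new or still open speak of the compounds shown alone.

Measured compounds in a functional assay on A549 cells (Homo sapiens) for antiproliferative activity, read by MTT assay, with a stated time of 48 h; a lower number here means a stronger inhibitor, a higher number a weaker inhibitor:
Compound 1 `CCc1ccccc1-n1nncc1CN1C(=O)C2(C(C#N)=C(N)Oc3c(N)cc4nc5ccccc5nc4c32)c2ccccc21`: 24600 nM
Compound 2 `N#CC1=C(N)Oc2c(N)cc3nc4ccccc4nc3c2C12C(=O)N(Cc1cnnn1-c1ccccc1Cl)c1ccccc12`: 29800 nM
Compound 3 `N#CC1=C(N)Oc2c(N)cc3nc4ccccc4nc3c2C12C(=O)N(Cc1cnnn1-c1ccccc1Br)c1ccccc12`: 27400 nM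

Compound 3 holds the second highest of the three numbers, and neither neighbour is separated from it beyond the scatter: a 1.1-fold lower number from compound 2 to compound 3 (0.04 log units; within the scatter) and a 1.1-fold higher number from compound 1 to compound 3 (0.05 log units; within the scatter). Compound 4 `CCOc1ccccc1-n1nncc1CN1C(=O)C2(C(C#N)=C(N)Oc3c(N)cc4nc5ccccc5nc4c32)c2ccccc21` has not yet been measured; it differs from compound 3 in one place: ethoxy in place of bromo on an aromatic carbon. Within the data shown here, the steps that bear on this change are a 1.2-fold higher number from compound 1 to compound 2 (0.08 log units; within the scatter), a 1.1-fold higher number from compound 1 to compound 3 (0.05 log units; within the scatter) and a 1.1-fold lower number from compound 2 to compound 3 (0.04 log units; within the scatter), all within the scatter, so exchanging one small group for another at this position has so far left this assay unchanged. Ethoxy is new here, but nothing in these steps points to a shift, so for compound 4 the expected step is a 1.0-fold lower number from compound 3 to compound 4 (0.01 log units; within the scatter). Compound 4 is therefore estimated at 27000 nM, with a range of 13000 nM to 56000 nM.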

Compound 4, half-maximal inhibitory concentration: > 50000 nM
Compound 4 was reported as a limit; the forecaster's own chance of this, stated with the estimate: 5%; middle value at least 1.8-fold (0.26 log units) away from the limit.
By their numbers in this assay, from the lowest: compounds 1, 3 and 2 (each within the scatter of the next). At a limit, above all of these: compound 4.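

In this assay, compound 4 is reported only as a limit, not a number: the limit of > 50000 nM in this assay, at which 1 of the 4 values shown sits. Its steps can be read only as floors: an at least 1.8-fold higher number from compound 3 to compound 4 (0.26 log units; that floor lies within the scatter), an at least 1.6-fold higher number from compound 2 to compound 4 (0.22 log units; that floor lies within the scatter) and an at least 2.0-fold higher number from compound 1 to compound 4 (0.30 log units; that floor lies within the scatter). So ethoxy is the first group at this position that may weaken the compound, whereas ethyl, chloro and bromo sit within the scatter of one another, but each floor also lies within the scatter, so a real loss is not shown.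

Open, from the compounds shown here alone, is how a methoxy group, a longer alkoxy chain or an amine at this position would read.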